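This account rests on a few compounds, and the source may have more. Where it says the series, first, only, none or still open, it means among the compounds named here.

Working notes on the series.

The shared core of compound 1 `CCCc1nc(C)c2c(C)nn(C)c(=O)n12` carries a propyl on one aromatic carbon, a methyl on a second and a methyl on a third, with a methyl on the ring nitrogen. In a functional assay for inhibition, with Homo sapiens as the target (on this read-out higher numbers stand for weaker inhibition and lower numbers for stronger inhibition), compound 1 gives > 48000 nM, which is a limit of the assay and not a number (the limit of > 48000 nM in this assay, at which 1 of the 3 values shown sits). Compound 2 `CCCc1nc(C)c2cnn(C)c(=O)n12` gives 20000 nM in this assay, and compound 3 `CCCc1nn(C)c(=O)n2c(CCC)nc(C)c12` gives 18000 nM. Within the measured set the two steps of an at least 2.4-fold lower number from compound 1 to compound 2 (0.38 log units; beyond the scatter) and an at least 2.6-fold lower number from compound 1 to compound 3 (0.42 log units; beyond the scatter) both run from the limit toward measured numbers, while the step of a 1.1-fold lower number from compound 2 to compound 3 (0.05 log units; within the scatter) stays within the scatter.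

Compound 4 `CCCc1nc(C)c2c(C)nn(CC(=O)OCC)c(=O)n12` is not yet measured. It differs from compound 1 by ethoxycarbonyl in place of hydrogen on a saturated chain carbon bound to an aromatic nitrogen. Within the data shown here, no measured step touches the saturated chain carbon bound to the aromatic nitrogen: the two steps from compound 1 sit on aromatic carbons and on the saturated chain bound to an aromatic carbon, and neither reaches far from the limit. On these numbers the expected step of an at least 1.2-fold lower number from compound 1 to compound 4 (0.07 log units; that floor lies within the scatter) in this assay is small or none beyond the scatter, with the limit itself a likely outcome. For compound 4 the estimated value in this assay is 40000 nM, expected between 10000 nM and 160000 nM.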

Compound 4, half-maximal inhibitory concentration: > 48000 nM
Compound 4: no number, only a limit; the forecaster's own chance of this, stated with the estimate: 55%; middle value at least 1.2-fold (0.07 log units) from the limit.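

In this assay compound 4 gives > 48000 nM as a limit of the assay and not a number. Compound 1 gives > 48000 nM as a limit too. The step between compound 1 and compound 4 therefore cannot be read: the limit of > 48000 nM in this assay, at which 2 of the 4 values shown sit.

From the compounds shown here alone, whether ethoxycarbonyl in place of hydrogen on a saturated chain carbon bound to an aromatic nitrogen changes inhibition at all stays open.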